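The source may hold more compounds than are shown below. What is called first, only, known or untested is meant among the compounds shown, and "the series" means these compounds.

In an ADME assay on microsomes from liver (Mus musculus) for metabolic stability, with a stated time of 10 min, tested at 0.5 uM (a lower number here means that less of the compound is left, a higher number that more of the compound is left), compound 1 `COc1ncc(NC(=O)[C@H](C)[C@H]2CC[C@@H](c3ccnc4ccc(F)cc43)CC2)cn1` gives 51%, and compound 2 `C[C@H](NC(=O)[C@H](C)[C@H]1CC[C@@H](c2ccnc3ccc(F)cc32)CC1)c1ccc(Cl)cc1` gives 5%. Compound 3 `C[C@@H](C(=O)NC1CCCCC1)[C@H]1CC[C@@H](c2ccnc3ccc(F)cc32)CC1` gives < 1%, a limit of the assay and not a number, and so it stands at the limit of < 1% in this assay, at which 1 of the 3 values shown sits.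

Compound 4 `C[C@@H](CNc1ccc(Cl)cc1)[C@H]1CC[C@@H](c2ccnc3ccc(F)cc32)CC1` differs from compound 3 by ((4-chlorophenyl)amino)methyl in place of cyclohexylcarbamoyl on a saturated chain carbon bound to a saturated chain carbon and a saturated ring carbon. Among the measured compounds shown here, no measured step makes this exchange, so the evidence is indirect. The measured steps all alter the group on the amide-type nitrogen. Two are large, a number 46 percentage points lower from compound 1 to compound 2 (beyond the scatter) and a number at least 50 percentage points lower from compound 1 to compound 3 (beyond the scatter), and both leave the 2-methoxypyrimidin-5-yl group of compound 1. Compound 4 also lacks that group, and the remaining step, a number at least 4 percentage points lower from compound 2 to compound 3 (that floor lies within the scatter), has a floor within the scatter. No step beyond the scatter is therefore expected, and the estimated change is a number at least 4 percentage points higher from compound 3 to compound 4 (that floor lies within the scatter). Compound 4 is expected to show 5%, with an estimated range from 0.5% to 22%.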

Compound 4, percent of the compound remaining: 80%
For compound 4 the middle estimate is 75 percentage points below the measured one, and the stated range ends below it.
By their numbers in this assay, from the lowest: compound 2; then compound 1; then compound 4. At a limit, below all of these: compound 3.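

On a saturated chain carbon bound to a saturated chain carbon and a saturated ring carbon, ((4-chlorophenyl)amino)methyl in place of cyclohexylcarbamoyl gives a number at least 79 percentage points higher from compound 3 to compound 4 (beyond the scatter) in this assay. The earlier steps shown here altered only the group on the amide-type nitrogen, whereas this one removes the carbonyl and replaces the non-aromatic carbon ring with an aromatic one, while the heavy-atom, donor and acceptor counts printed for the two groups stay the same, so the read-out responds strongly to a change that these counts do not register. Compound 3 stands at a limit of the assay and not at a number, so the true size of the step stays unknown: the limit of < 1% in this assay, at which 1 of the 4 values shown sits.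

The compounds shown leave open whether the loss of the carbonyl or the exchange of rings carries the step, as both change together. A (cyclohexylamino)methyl group in this place would separate the two.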